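Ethyl for Methyl on the Piperidine Side Chain

The compounds below may be only part of what the source reports. "The series", "measured", "known", "first", "only" and "open" are said of these compounds alone.

Compound 3 `Cc1cc(C)cc(-c2c(O)nc3cc(Cl)c([N+](=O)[O-])cc3c2OCCC2CCC(C)CN2)c1` gives 63 nM in an assay on isolated protein for inhibition of Gonadotropin-releasing hormone receptor (Rattus norvegicus) (a lower number here means a stronger inhibitor, a higher number a weaker inhibitor), the lowest of the three numbers shown. Compound 1 `Cc1cc(C)cc(-c2c(O)nc3cc(Cl)c([N+](=O)[O-])cc3c2OCC[C@@H]2Cc3ccccc3CN2)c1` gives 70 nM, with a 1.1-fold lower number from compound 1 to compound 3 (0.05 log units; within the scatter). Compound 2 `Cc1cc(C)cc(-c2c(O)nc3cc(Cl)c([N+](=O)[O-])cc3c2OCCC2NCCc3ccccc32)c1` gives 750 nM, and the steps of an 11-fold higher number from compound 1 to compound 2 (1.03 log units; beyond the scatter) and a 12-fold lower number from compound 2 to compound 3 (1.08 log units; beyond the scatter) show how strongly this assay responds to which ring is carried at that chain carbon. Compound 4 `CC[C@H]1CCC[C@@H](CCOc2c(-c3cc(C)cc(C)c3)c(O)nc3cc(Cl)c([N+](=O)[O-])cc23)N1` differs from compound 3 in one place: 6-ethylpiperidin-2-yl in place of 5-methylpiperidin-2-yl on a saturated chain carbon, two bonds along the chain from an oxygen on an aromatic ring. Going by the values given here, no measured step matches this change; the step from compound 1 to compound 3 is small, while the steps involving compound 2 are large. Compound 4 is therefore expected to give 80 nM (range 25 nM to 250 nM), an estimated step of a 1.3-fold higher number from compound 3 to compound 4 (0.10 log units; within the scatter) within the scatter.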

Compound 4, half-maximal inhibitory concentration: 18 nM
Compound 4: the middle estimate sits 4.4-fold (0.65 log units) above what was measured; the whole stated range lies above it.
By their numbers in this assay, from the lowest: compound 4; then compounds 3 and 1 (each within the scatter of the next); then compound 2.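

In this assay, the ring on this chain carbon can lower the number further, not only hold it or raise it: 6-ethylpiperidin-2-yl gives a 3.5-fold lower number from compound 3 to compound 4 (0.54 log units; beyond the scatter), along with a 3.9-fold lower number from compound 1 to compound 4 (0.59 log units; beyond the scatter) and a 42-fold lower number from compound 2 to compound 4 (1.62 log units; beyond the scatter). Compound 4 thus lies beyond the scatter of every other compound shown, which no earlier ring achieved. No evidence is available that bears on this gain.

Still open, on these data alone, is whether the gain follows the ethyl or its ring position, which 6-methylpiperidin-2-yl or 5-ethylpiperidin-2-yl would separate. Also open, as far as these compounds go, is whether a longer chain, such as 6-propylpiperidin-2-yl, lowers the number further.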